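The compounds below may be only part of what the source reports. "The series", "measured", "known", "first", "only" and "open" are said of these compounds alone.

Measured in an ADME assay on HEK293 cells (Homo sapiens) for cytotoxicity, read by MTT assay, with a stated time of 24 h; a lower number here means a stronger inhibitor, a higher number a weaker inhibitor:
- compound 1 `O=[N+]([O-])c1ccc2nc(NCc3ccc(C(F)(F)F)cc3)c(N3CCNCC3)nc2c1`: 9.61 ug/mL
- compound 2 `COc1ccc(CNc2nc3ccc([N+](=O)[O-])cc3nc2NCCCN(C)C)cc1`: 38.6 ug/mL

Compound 2 holds the higher of the two numbers at 38.6 ug/mL, which makes it the weaker inhibitor in this assay. Compound 1 lies lower at 9.61 ug/mL, a gap beyond the usual scatter. The two compounds differ in more than one place, so this gap cannot be assigned to any single structural change.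

The next compound is compound 3 `CN(C)CCCNc1nc2cc([N+](=O)[O-])ccc2nc1NCc1ccc(Cl)c(C(F)(F)F)c1`. Its difference from compound 2 is 4-chloro-3-(trifluoromethyl)phenyl in place of 4-methoxyphenyl on a saturated chain carbon bound to a nitrogen on an aromatic ring.

Going by the values given here, no measured pair isolates a change of this kind, so the expectation is weakly founded. Among the compounds with values here, its only guide is compound 1, which also carries a trifluoromethyl group and reads 9.61 ug/mL. A lower number in this assay is therefore expected, by a step modestly beyond the scatter, although no real change cannot be ruled out. The estimate corresponds to an expected step of a 2.4-fold lower number from compound 2 to compound 3 (0.38 log units; beyond the scatter). For compound 3 the estimated value is 16 ug/mL, with an expected range of 6 ug/mL to 40 ug/mL.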

Compound 3, half-maximal inhibitory concentration: 3.26 ug/mL
For compound 3 the middle estimate is 4.9-fold (0.69 log units) above the measured one; measured number outside the range, below it.
By their numbers in this assay, from the lowest: compound 3; then compound 1; then compound 2.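

In this assay, the aromatic group on a saturated chain carbon bound to a nitrogen on an aromatic ring proves to be a sensitive position: 4-chloro-3-(trifluoromethyl)phenyl in place of 4-methoxyphenyl gives a 12-fold lower number from compound 2 to compound 3 (1.07 log units; beyond the scatter) with the rest of the structure unchanged. Going by these compounds alone, this is the first pair that differs in one place, so it is the first reading tied to a single structural change, and the large size of the step shows that this position alone can move the number well beyond the scatter. No measurement shown explains why this change produces such a step.

The chlorine and the trifluoromethyl enter together while the methoxy leaves, so the share of each remains unresolved, and a plain phenyl group at this position would give a reference point for separating them. As far as these compounds go, it also remains open whether the same change gives a step of similar size when a piperazine, as in compound 1, stands in place of the dimethylaminopropyl amine chain.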